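Swapping Methoxy for Cyano on the Shared Core

The source may hold more compounds than are shown below. What is called first, only, known or untested is meant among the compounds shown, and "the series" means these compounds.

Compound 1 `Cc1nc(N)nc2c1c(-c1ccc3oc(N)nc3c1)nn2C(C)C`, compound 2 `CCc1nc(N)nc2c1c(-c1ccc3oc(N)nc3c1)nn2C(C)C` and compound 3 `COc1nc(N)nc2c1c(-c1ccc3oc(N)nc3c1)nn2C(C)C` share one core and differ in a single group on it. In a physicochemical assay for solubility, read by HPLC, in phosphate buffer, measured as kinetic solubility, with a stated time of 24 h, at 20 degrees C, at pH 7.4, tested at 100 uM (on this read-out lower numbers stand for lower solubility and higher numbers for higher solubility), compound 1 gives 74000 nM and compound 2 gives 62000 nM, a change of a 1.2-fold lower number from compound 1 to compound 2 (0.08 log units; within the scatter). For compound 3 the result is a limit of the assay, < 1000 nM, the one noted as the limit of < 1000 nM in this assay, at which 1 of the 3 values shown sits. The step of an at least 74-fold lower number from compound 1 to compound 3 (1.86 log units; beyond the scatter) and the step of an at least 62-fold lower number from compound 2 to compound 3 (1.79 log units; beyond the scatter) are both large, and compound 3 stands at the bottom of the measured set, with only a limit known. Compound 4 `CC(C)n1nc(-c2ccc3oc(N)nc3c2)c2c(C#N)nc(N)nc21` differs from compound 3 by cyano in place of methoxy on an aromatic carbon. Going by the values given here, no measured step involves a cyano group; the only guide is the pair of large steps from methyl or ethyl to methoxy, which show that a change at this one position can move the solubility strongly. The expectation for compound 4 is a step of an at least 10-fold higher number from compound 3 to compound 4 (1.00 log units; beyond the scatter), upward, with a wide range. Compound 4 is therefore estimated at 10000 nM, between 1000 nM and 60000 nM.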

Compound 4, solubility: < 1000 nM
Compound 4: only a limit was reported; the forecaster's own chance of this, stated with the estimate: 25%; middle value at least 10-fold (1.00 log units) away from the limit.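

In this assay compound 4 gives < 1000 nM, a limit of the assay and not a number, and with it a second group on this aromatic carbon reaches that limit: the limit of < 1000 nM in this assay, at which 2 of the 4 values shown sit. Cyano in place of ethyl gives an at least 62-fold lower number from compound 2 to compound 4 (1.79 log units; beyond the scatter), and cyano in place of methyl gives an at least 74-fold lower number from compound 1 to compound 4 (1.86 log units; beyond the scatter), so among the four compounds shown the high numbers belong only to the two carrying methyl or ethyl. Compound 3 and compound 4 both sit at a limit, so the step between them cannot be read and no order of methoxy and cyano follows.

Going by these compounds, it remains open how far under the limit these two compounds lie. On these data alone, it also remains open whether a longer chain such as propyl, or an amine, on this carbon would keep the high numbers of compound 1 and compound 2.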